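The source may hold more compounds than are shown below. What is called first, only, known or untested is meant among the compounds shown, and "the series" means these compounds.

Measured so far: compound 1 `O=C(CCCc1ccccc1)Nc1nc2ccccc2c(=O)s1` gives 34.9 nM in an in vitro assay on cells for inhibition of Amine oxidase [flavin-containing] B (Homo sapiens), read by fluorescence and Amplex Red, with stated times of 30 min and 45 min; a higher number here means a weaker inhibitor, a lower number a stronger inhibitor; compound 2 `O=C(CCCc1ccccc1)Nc1nc2ccc(Br)cc2c(=O)s1` gives > 10000 nM in this assay.

Where compound 2 stands: its value in this assay is a limit of the assay, not a number, as the limit of > 10000 nM in this assay, at which 1 of the 2 values shown sits, records. Compound 2 therefore sits only as a limit, and the step of an at least 280-fold higher number from compound 1 to compound 2 (2.45 log units; beyond the scatter) is itself a lower bound on the loss that bromo in place of hydrogen on an aromatic carbon brings in this series.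

The next compound is compound 3 `Cc1ccc2nc(NC(=O)CCCc3ccccc3)sc(=O)c2c1`, not yet measured in this assay. It differs from compound 2 by methyl in place of bromo on an aromatic carbon. Within the data shown here, no measured step covers methyl in place of bromo at this position; the only step that bears on the change is an at least 280-fold higher number from compound 1 to compound 2 (2.45 log units; beyond the scatter), which shows that substitution at this aromatic carbon can carry a large penalty. Methyl is a different group from bromo, so the size of the penalty for compound 3 is open; it may fall anywhere between compound 1 and the limit held by compound 2.

The estimate for compound 3 in this assay is 3000 nM, with a range from 200 nM to 30000 nM. The step of an at least 3.3-fold lower number from compound 2 to compound 3 (0.52 log units; beyond the scatter) is the expected gain, uncertain in size because compound 2 stands at a limit.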

Compound 3, half-maximal inhibitory concentration: 94 nM
The estimate for compound 3 lay 32-fold (1.50 log units) above the measured number; the whole stated range lies above it.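

Substitution on this aromatic carbon is not barred as such: in this assay, methyl in place of hydrogen gives a 2.7-fold higher number from compound 1 to compound 3 (0.43 log units; beyond the scatter), a modest step beyond the scatter. The large loss that came with bromo therefore does not extend to every group at this position, and the exchange of bromo for methyl, two groups of one heavy atom each, gives an at least 100-fold lower number from compound 2 to compound 3 (2.02 log units; beyond the scatter). The size of that recovery remains a lower bound, since compound 2 is held only as a limit of the assay: the limit of > 10000 nM in this assay, at which 1 of the 3 values shown sits.

Hydrogen, methyl and bromo are the only groups shown at this carbon, so it remains open whether chloro, methoxy, an amine or a carboxylic acid would stay close to methyl or fall away as bromo does. The compounds shown also leave open whether the same separation between methyl and bromo would hold with a shorter chain on the amide, or with methyl on another carbon of the same six-membered aromatic ring.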